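Replacing 2-chlorophenyl with 4-fluorophenyl on a carbonyl carbon

The source may report more compounds than this note shows. Statements on the series, on what has been measured and on what is new or still open speak of the compounds shown alone.

Compound 1 (`O=C(NNc1ccccc1F)c1ccc(NS(=O)(=O)c2cnc(O)nc2O)cc1`) reads > 20000 nM in a functional assay on OVCAR-3 cells (Homo sapiens) for antiproliferative activity, read by MTT assay, with a stated time of 24 h (on this read-out lower numbers stand for stronger inhibition and higher numbers for weaker inhibition), and this is a limit of the assay. For the measured compounds named here, compound 2 (`O=C(NNC(=O)c1ccccc1Cl)c1ccc(NS(=O)(=O)c2cnc(O)nc2O)cc1`) gives 5220 nM in this assay as the only true number so far, and so it has no other measured value to be ranked against. Going by the values given here, the one measured step is an at least 3.8-fold lower number from compound 1 to compound 2 (0.58 log units; beyond the scatter) and it brings in a (2-chlorophenyl)carbonyl on an amine nitrogen in place of 2-fluorophenyl. From the compounds shown here alone, its exact size stays open because the limit of > 20000 nM in this assay, at which 1 of the 2 values shown sits, applies to compound 1.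

Compound 3 (`O=C(NNC(=O)c1ccc(NS(=O)(=O)c2cnc(O)nc2O)cc1)c1ccc(F)cc1`) carries 4-fluorophenyl in place of 2-chlorophenyl on a carbonyl carbon whose other neighbour is an amide-type nitrogen. Among the compounds with values here, no measured step tests this exchange alone. Compound 3 keeps the carbonyl that arrived with an at least 3.8-fold lower number from compound 1 to compound 2 (0.58 log units; beyond the scatter) and so it is expected to stay close to compound 2 rather than fall back to the limit. The expected outcome is a 1.2-fold higher number from compound 2 to compound 3 (0.10 log units; within the scatter) in this assay with no clear direction. Compound 3 is estimated at about 6500 nM in this assay with 2500 nM to 17000 nM as the expected range.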

Compound 3, half-maximal inhibitory concentration: > 20000 nM
Compound 3 ended at the assay's limit (the forecaster's own chance of this, stated with the estimate: 15%); at least 3.0-fold (0.48 log units) between middle value and limit.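

Keeping the carbonyl on the amine nitrogen is not enough on its own to hold a measurable reading: placing 4-fluorophenyl in place of 2-chlorophenyl on this carbonyl carbon, whose other neighbour is an amide-type nitrogen, gives an at least 3.8-fold higher number from compound 2 to compound 3 (0.58 log units; beyond the scatter) in this assay. The group on this carbonyl carbon therefore matters to the reading, and of the two groups shown here, only 2-chlorophenyl gives a true number. Compound 3 stands at a limit of the assay, > 20000 nM in this assay, as does compound 1, and the step that links them cannot be read: the limit of > 20000 nM in this assay, at which 2 of the 3 values shown sit.

The exchange alters both the halogen and its printed ring position at once, so the compounds shown leave open which of the two accounts for the step, a question that 4-chlorophenyl or 2-fluorophenyl on this same carbonyl carbon would address. They also leave open how an unsubstituted phenyl or a 2-methoxyphenyl would read here, and whether any group at this position could give a lower number than 2-chlorophenyl.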